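A few compounds are considered here, and "the series" means these few. Any claim that something is new, unique, unknown or untested is made for them only; others in the source may bear on it.

Within the data shown here, in a functional assay on A549 cells (Homo sapiens) for inhibition, read by MTT assay, with a stated time of 96 h (a lower number here means a stronger inhibitor of growth, a higher number a weaker inhibitor of growth), compound 1 `O=C(OCc1ccccc1)SCCCCCCNC(=O)c1cc(-c2ccncc2)n[nH]1` gives 13400 nM and compound 2 `CCCC(=O)SCCCCCCNC(=O)c1cc(-c2ccncc2)n[nH]1` gives 15100 nM, so compound 2 stands level with the only other measured compound, within the scatter. Compound 3 `CCC(=O)SCCCCCCNC(=O)c1cc(-c2ccncc2)n[nH]1` differs from compound 2 by hydrogen in place of methyl on a saturated chain carbon, two bonds along the chain from a carbonyl carbon. Among the measured compounds shown here, one measured step bears on this change, a 1.1-fold higher number from compound 1 to compound 2 (0.05 log units; within the scatter). It exchanged benzyloxy for propyl on that same carbonyl carbon, a larger structural change than the one here, and it stayed within the scatter. For the measured compounds named here, no measured step shortens the chain itself, so the support is thin. No step beyond the scatter is expected in this assay. The estimate amounts to a 1.0-fold lower number from compound 2 to compound 3 (0.00 log units; within the scatter), an expected change within the scatter. Compound 3 is estimated at 15000 nM, with an expected range of 8000 nM to 28000 nM.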

Compound 3, concentration for 50% growth inhibition: > 50000 nM
Compound 3: only a limit was reported; the forecaster's own chance of this, stated with the estimate: 5%; middle value at least 3.3-fold (0.52 log units) away from the limit.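

For compound 3 the reading in this assay is only a limit of the assay: the limit of > 50000 nM in this assay, at which 1 of the 3 values shown sits. Propanoyl in place of the propylcarbonyl group gives an at least 3.3-fold higher number from compound 2 to compound 3 (0.51 log units; beyond the scatter), so this chain responds to the loss of a single carbon, which the earlier pair did not show. Ethyl in place of benzyloxy on the carbonyl carbon gives an at least 3.7-fold higher number from compound 1 to compound 3 (0.57 log units; beyond the scatter), whereas propyl in place of benzyloxy stayed within the scatter, so compound 1 and compound 2 read level and compound 3 stands apart from both.

As far as these compounds go, it stays open whether a longer chain such as butyl holds the level of compound 2, and whether an acetyl group, with methyl on the carbonyl carbon, reads like compound 3. From the compounds shown here alone, the true value of compound 3 also stays open, so both new steps are known only as bounds.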